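An ether-linked sulfamide chain on the shared core

The source may report more compounds than this note shows. Statements on the series, on what has been measured and on what is new or still open speak of the compounds shown alone.

Compound 3 `CSc1nonc1/C(=N/O)Nc1ccc(F)c(Br)c1` gives 15 nM in an assay for inhibition of Indoleamine 2,3-dioxygenase 1 (Homo sapiens), read by fluorescence, with a stated time of 24 h (a higher number here means a weaker inhibitor, a lower number a stronger inhibitor), and so stands second highest of the three measured numbers: compound 1 `COc1nonc1/C(=N/O)Nc1ccc(F)c(Br)c1` gives 39 nM and compound 2 `NS(=O)(=O)NCCSc1nonc1/C(=N/O)Nc1ccc(F)c(Br)c1` gives 2.8 nM. Compound 4 `NS(=O)(=O)NCCOc1nonc1/C(=N/O)Nc1ccc(F)c(Br)c1` carries 2-(sulfamoylamino)ethoxy in place of methylsulfanyl on an aromatic carbon. Going by the values given here, two measured steps bear on this change: attaching the long chain gave a 14-fold lower number from compound 1 to compound 2 (1.14 log units; beyond the scatter), while cutting it back to hydrogen gave a 5.4-fold higher number from compound 2 to compound 3 (0.73 log units; beyond the scatter). The exchange of sulfur for oxygen at the ring, however, runs against a 2.6-fold lower number from compound 1 to compound 3 (0.41 log units; beyond the scatter). A lower number, somewhat smaller than the gain seen for compound 2, is therefore expected, a 2.1-fold lower number from compound 3 to compound 4 (0.33 log units; beyond the scatter). Compound 4 is expected to give 7 nM in this assay, between 2.5 nM and 20 nM.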

Compound 4, half-maximal inhibitory concentration: 12 nM
Compound 4: middle estimate off by 1.7-fold (0.23 log units), on the low side; low and high end bracket the measured number.
By their numbers in this assay, from the lowest: compound 2; then compounds 4 and 3 (each within the scatter of the next); then compound 1.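

Replacing methylsulfanyl with 2-(sulfamoylamino)ethoxy leaves the number almost unchanged (a 1.3-fold lower number from compound 3 to compound 4 (0.10 log units; within the scatter)), so on the shared core this long chain on oxygen and the small group on sulfur cannot be told apart. With the chain in place, the linking atom does matter (a 4.3-fold higher number from compound 2 to compound 4 (0.63 log units; beyond the scatter)), yet the chain still helps on oxygen (a 3.3-fold lower number from compound 1 to compound 4 (0.51 log units; beyond the scatter)). Its gain is of similar size on both links: the same change on two cores in this assay, a 5.4-fold higher number (0.73 log units; beyond the scatter) from compound 2 to compound 3 and a 3.3-fold higher number (0.51 log units; beyond the scatter) from compound 4 to compound 1, 1.6-fold (0.22 log units) apart, within the scatter of two such steps.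

Open, from the compounds shown here alone, is whether a longer chain, or a carboxylic acid in place of the sulfamoylamino end, would keep this gain.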